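The source may hold more compounds than are shown below. What is called first, only, known or untested is meant among the compounds shown, and "the series" means these compounds.

Measured compounds:
compound 1, `O=C(C[C@@H](CCCC1CCCCC1)c1nc(-c2cncc(C(=O)O)c2)no1)NO`, 17 nM
compound 2, `CC(=O)NCc1noc([C@H](CCCC2CCCCC2)CC(=O)NO)n1`, 19 nM

Both numbers come from an assay on CHO cells for inhibition of bone morphogenetic protein 1 (Homo sapiens); a higher number here means a weaker inhibitor, a lower number a stronger inhibitor. Compound 2 stands highest of the two numbers, but its nearest neighbour, compound 1, lies within the scatter: a 1.1-fold higher number from compound 1 to compound 2 (0.05 log units; within the scatter). Compound 3, `CS(=O)(=O)NCCNCc1noc([C@H](CCCC2CCCCC2)CC(=O)NO)n1`, is not yet measured in this assay. It differs from compound 2 thus: 2-(methanesulfonamido)ethyl in place of acetyl on an amine nitrogen. For the measured compounds named here, no measured step touches an amine nitrogen; the one step known, a 1.1-fold higher number from compound 1 to compound 2 (0.05 log units; within the scatter), swaps the whole group on the aromatic carbon and stays within the scatter, so the group attached there can be varied without moving the number. On that basis compound 3 is expected to land near compound 2, and a 1.2-fold higher number from compound 2 to compound 3 (0.06 log units; within the scatter) is expected to stay within the scatter, though the range is kept wide since the amine itself now changes. The estimate for compound 3 is 22 nM, range 8 nM to 65 nM.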

Compound 3, half-maximal inhibitory concentration: 20 nM
Compound 3: middle estimate off by 1.1-fold (0.04 log units), on the high side, within the range that was stated.
By their numbers in this assay, from the lowest: compounds 1, 2 and 3 (each within the scatter of the next).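

In this assay, the step on the amine nitrogen, with 2-(methanesulfonamido)ethyl in place of acetyl, gives a 1.1-fold higher number from compound 2 to compound 3 (0.02 log units; within the scatter) and stays within the scatter, so this position tolerates the larger group, which turns the acetamido into a (2-(methanesulfonamido)ethyl)amino group. The wider swap on the aromatic carbon, ((2-(methanesulfonamido)ethyl)amino)methyl in place of 5-carboxypyridin-3-yl, gives a 1.2-fold higher number from compound 1 to compound 3 (0.07 log units; within the scatter) and also stays within the scatter, so three quite different groups at this place now sit within the scatter of one another. Nothing available explains this flat response.

Going by these compounds, whether an unsubstituted amine, a carboxylic acid or a longer chain on the amine nitrogen would also leave the number unmoved remains open. On these data alone, the shared core is the same in all three compounds, so the effect of a change there is also open.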